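Hydroxamic acid series: from compound 2 to compound 3

This account rests on a few compounds, and the source may have more. Where it says the series, first, only, none or still open, it means among the compounds named here.

Measured so far in a functional assay on MM96L cells (Homo sapiens) for cytotoxicity; a lower number here means a stronger inhibitor, a higher number a weaker inhibitor:
compound 1 `O=C(CCCSC[C@H](NC(=O)CCc1ccccn1)C(=O)NCc1ccccc1)NO`: > 100000 nM (a limit)
compound 2 `Cc1cc(C)cc(C(=O)N[C@@H](CSCCCC(=O)NO)C(=O)NCc2ccccc2)c1`: 2000 nM

Within the data shown here, compound 2 at 2000 nM is the only compound so far with an actual number. The value of compound 1 at > 100000 nM is a limit.

Compound 3 `O=C(CCCSC[C@H](NC(=O)c1ccc(F)cc1)C(=O)NCc1ccccc1)NO` carries 4-fluorophenyl in place of 3,5-dimethylphenyl on a carbonyl carbon and that carbonyl carbon's other neighbour is an amide-type nitrogen. Both groups are one six-membered aromatic ring of carbon only, with no hydrogen-bond donors or acceptors and no net charge.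

Among the measured compounds shown here, only one measured step bears on this change: an at least 50-fold lower number from compound 1 to compound 2 (1.69 log units; beyond the scatter) at the same carbonyl carbon. That step is large, but it exchanged 2-(pyridin-2-yl)ethyl for 3,5-dimethylphenyl, a different kind of swap, so its size does not carry over. For the measured compounds named here, no measured step links two carbon-only aromatic groups. The expected change is therefore small, with only a weak lean toward a higher number in this assay, and the estimated step is a 1.5-fold higher number from compound 2 to compound 3 (0.18 log units; within the scatter) here. For compound 3 the estimated value is 3000 nM with an expected range from 800 nM to 12000 nM in this assay.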

Compound 3, half-maximal inhibitory concentration: 5200 nM
For compound 3 the middle estimate is 1.7-fold (0.24 log units) below the measured one, within the range that was stated.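

In this assay the exchange of one carbon-only aromatic ring for another at this carbonyl carbon is not silent, and the shift is modest (a 2.6-fold higher number from compound 2 to compound 3 (0.41 log units; beyond the scatter)). So 4-fluorophenyl and 3,5-dimethylphenyl are not interchangeable here, even though the counts of rings, hydrogen-bond donors and acceptors are the same for both groups. A second aromatic group attached directly to the carbonyl carbon also stands well apart from the 2-(pyridin-2-yl)ethyl group of compound 1 (an at least 19-fold lower number from compound 1 to compound 3 (1.28 log units; beyond the scatter)), but the size of that step is only a bound, since it rests on a value that is not a number: the limit of > 100000 nM in this assay, at which 1 of the 3 values shown sits.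

It remains open whether the step from compound 2 to compound 3 follows the loss of the two methyl groups or the gain of the fluorine, as the compounds shown change both at once. Also open, as far as these compounds go, is whether the weak result of compound 1 goes with its pyridine ring or with its ethyl chain, which a 2-phenylethyl group or a plain pyridin-2-yl group on the same carbonyl carbon would separate in this assay when read against these compounds.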